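Replacing 2-bromo-5-ethoxyphenyl with 4-fluorophenyl on the shared core

This account rests on a few compounds, and the source may have more. Where it says the series, first, only, none or still open, it means among the compounds named here.

In a functional assay on MCF7 cells (Homo sapiens) for inhibition, read by MTT assay, with a stated time of 48 h, tested at 10 uM (a higher number here means more inhibition of growth at the concentration tested, a lower number less inhibition of growth), compound 3 (`CCOc1ccc(Br)c(C(O)c2c(C)oc3c([C@H]4CCN(C)C[C@H]4O)c(O)cc(O)c3c2=O)c1`) stands lowest of the three measured compounds at 9% while compound 2 (`Cc1oc2c([C@H]3CCN(C)C[C@H]3O)c(O)cc(O)c2c(=O)c1C(O)c1csc([N+](=O)[O-])c1`) reaches 20% and compound 1 (`Cc1oc2c([C@H]3CCN(C)C[C@H]3O)c(O)cc(O)c2c(=O)c1C(O)c1c(F)cccc1Cl`) reaches 41% on the same core. The unmeasured compound 4 (`Cc1oc2c([C@H]3CCN(C)C[C@H]3O)c(O)cc(O)c2c(=O)c1C(O)c1ccc(F)cc1`) has 4-fluorophenyl in place of 2-bromo-5-ethoxyphenyl on a saturated chain carbon bound to an aromatic carbon and an oxygen on a saturated carbon. All three measured steps change this same group. The largest is the step to the 2-bromo-5-ethoxyphenyl group (a number 32 percentage points lower from compound 1 to compound 3 (beyond the scatter)). The two others are modest (a number 21 percentage points lower from compound 1 to compound 2 (beyond the scatter)) and (a number 11 percentage points lower from compound 2 to compound 3 (beyond the scatter)). Within the data shown here, no measured compound carries 4-fluorophenyl, so the closest guide is the 2-chloro-6-fluorophenyl group of compound 1 (41%), and a modest rise is expected, in size like the smaller steps. The expected step in this assay is (a number 19 percentage points higher from compound 3 to compound 4 (beyond the scatter)). Compound 4 is estimated at 28% with an expected range of (10% to 48%).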

Compound 4, percent growth inhibition at one concentration: 9%
Estimate against measurement, compound 4: 19 percentage points above; measured number outside the range, below it.
By their numbers in this assay, from the lowest: compounds 3 and 4 (each within the scatter of the next); then compound 2; then compound 1.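

In this assay, 4-fluorophenyl on the saturated chain carbon shows no change at the digits printed from compound 3 to compound 4 (within the scatter), so a fluorine on the phenyl ring is not enough to separate this group from 2-bromo-5-ethoxyphenyl, although the two share no ring substituent. Among these compounds, the same group gives a number 11 percentage points lower from compound 2 to compound 4 (beyond the scatter) and a number 32 percentage points lower from compound 1 to compound 4 (beyond the scatter), so a phenyl ring as such does not set the level here: the 2-chloro-6-fluorophenyl group of compound 1 stands highest of the four, yet the 5-nitrothiophen-3-yl group of compound 2, the only group without a phenyl ring, exceeds both compound 3 and compound 4. No evidence is available to explain these differences.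

The compounds shown leave open whether the higher number of compound 1 needs both its chlorine and its fluorine or only one of them. They also leave open how a phenyl ring bearing an amine or a carboxylic acid would read at this position in this assay.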